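The source may hold more compounds than are shown below. What is called first, only, known or untested is meant among the compounds shown, and "the series" means these compounds.

Compound 1 `CCN(Cc1ccc(Br)cc1)c1cccc(C(=O)N2CCc3ccc(OS(N)(=O)=O)cc3C2)c1` is the starting point of this step. For the measured compounds named here, in an assay on HEK293 cells for inhibition of Steryl-sulfatase (Homo sapiens), tested at 1 uM (on this read-out lower numbers stand for a weaker effect and higher numbers for a stronger effect at the one concentration tested), compound 1 gives 84.5%, the second highest of the three numbers measured so far. Compound 2 `CC(C)CCN(CCC(C)C)c1ccc(C(=O)N2CCc3ccc(OS(N)(=O)=O)cc3C2)cc1` gives 90.8%, within the scatter of compound 1, so no order between the two can be claimed. Compound 3 `NS(=O)(=O)Oc1ccc2c(c1)CN(C(=O)c1ccc(N3CCCCC3)cc1)CC2` gives 38.3%, well below compound 1. Going by the values given here, the only single-place step measured is a number 52.5 percentage points lower from compound 2 to compound 3 (beyond the scatter), a large fall.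

Compound 4 `CN(CCN1CCCCC1)c1cccc(C(=O)N2CCc3ccc(OS(N)(=O)=O)cc3C2)c1` differs from compound 1 in one place: methyl(2-(piperidin-1-yl)ethyl)amino in place of (4-bromobenzyl)(ethyl)amino on an aromatic carbon. The measured step from compound 2 to compound 3 bears on this only loosely: there an open-chain dialkylamino was traded for a ring-closed amine and the read-out dropped sharply, whereas here the amino stays open-chain and a piperidin-1-yl appears only at the end of the ethyl chain. Compound 2 with its open-chain diisopentylamino shows that a fully non-aromatic amino substituent can still give a high number, while compound 3 shows that not every amine does. Among the compounds with values here, a downward step is therefore expected, but smaller than the one from compound 2 to compound 3; the expected step is a number 19.5 percentage points lower from compound 1 to compound 4 (beyond the scatter). Compound 4 is estimated at 65%, with a range from 35% to 90%.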

Compound 4, a percentage reported as inhibition, at one concentration (the size of the read-out at that concentration, not a potency): 30.8%
Compound 4: middle estimate off by 34.2 percentage points, on the high side, outside the stated range (below it).
By their numbers in this assay, from the lowest: compounds 4 and 3 (each within the scatter of the next); then compounds 1 and 2 (each within the scatter of the next).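

In this assay, the position meta to a large group on the aromatic ring does not tolerate every open-chain amino substituent: methyl(2-(piperidin-1-yl)ethyl)amino in place of (4-bromobenzyl)(ethyl)amino gives a number 53.7 percentage points lower from compound 1 to compound 4 (beyond the scatter). The earlier large fall came with a ring-closed amine, so this step shows that keeping the amino nitrogen open-chain does not by itself hold the read-out, and the heavy-atom count of the substituent barely moves. The swap removes the six-membered aromatic ring of carbon only and the bromine and brings in a second nitrogen and a six-membered non-aromatic ring all at once, and nothing available here accounts for the fall or assigns it to any one of these parts.

Open, as far as these compounds go, is which part of the swap goes with the lower number, the loss of the 4-bromobenzyl or the arrival of the piperidin-1-yl at the end of the ethyl chain. An unsubstituted benzyl, a 4-chlorobenzyl, or a plain pentyl chain on the same amino nitrogen would begin to separate these parts at this position.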